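From a 4-fluorophenyl group to hydrogen on a ring amine

This account rests on a few compounds, and the source may have more. Where it says the series, first, only, none or still open, it means among the compounds named here.

Compound 1 (`Fc1ccc(N2CCN(c3nc(-n4ccc5ccccc54)c4ccccc4n3)CC2)cc1`) was tested in a functional assay on DU-145 cells (Homo sapiens) for antiproliferative activity, read by MTT assay (on this read-out higher numbers stand for weaker inhibition and lower numbers for stronger inhibition), where compound 1 gives 50 ug/mL. Among the compounds with values here, only one other tested compound is available for comparison. Compound 2 (`COc1ccc(-c2nc(N3CCNCC3)nc3ccccc23)c(OC)c1`) gives 50 ug/mL in this assay, so compound 1 stands level with compound 2, and the two cannot be told apart on these numbers.

Compound 3 (`c1ccc2c(c1)ccn2-c1nc(N2CCNCC2)nc2ccccc12`) has not yet been measured in this assay. It keeps the core of compound 1 but has hydrogen in place of 4-fluorophenyl on an amine nitrogen in a ring.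

Within the data shown here, no measured pair in this small set shows what such a change does, so any expectation remains weakly supported. Among the measured compounds shown here, with compound 1 at 50 ug/mL and compound 2 at 50 ug/mL, the only guide is that both tested compounds sit at the same level. No step beyond the scatter is therefore expected in this assay, in either direction. The expected step is a 1.3-fold lower number from compound 1 to compound 3 (0.10 log units; within the scatter). For compound 3 the estimated value is 40 ug/mL, with an expected range from 15 ug/mL to 90 ug/mL.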

Compound 3, half-maximal inhibitory concentration: 12.5 ug/mL
Compound 3: middle estimate off by 3.2-fold (0.51 log units), on the high side; the measured number lies below the stated range.
By their numbers in this assay, from the lowest: compound 3; then compounds 1 and 2 (each within the scatter of the next).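

In this assay, hydrogen in place of 4-fluorophenyl on the amine nitrogen in the ring gives a 4.0-fold lower number from compound 1 to compound 3 (0.60 log units; beyond the scatter), a modest step but one beyond the scatter, which shows that this position can change the read-out and that the large aromatic group is not needed there for inhibition of this level. Hydrogen on that nitrogen is not enough by itself, however: the other compound with hydrogen there, which differs from compound 3 in the large group on the core, is compound 2 at 50 ug/mL, so the lower number appears only in combination with the group that compound 3 keeps from compound 1. Nothing measured here explains the step.

From the compounds shown here alone, with a single change at this nitrogen, it remains open whether the step follows from losing the 4-fluorophenyl group or from having hydrogen there, and a methyl group, an acetyl group or a longer chain at the same nitrogen would help separate the two. Going by these compounds, it also remains open whether the same step would appear on compound 2's side of the series, or in cell lines other than this one.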